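From fluoro to trifluoromethyl on an aromatic carbon

This account rests on a few compounds, and the source may have more. Where it says the series, first, only, none or still open, it means among the compounds named here.

Of the compounds shown here, three sharing one core have been measured in a functional assay on MIA PaCa-2 cells (Homo sapiens) for inhibition, read by MTT assay; on this read-out lower numbers stand for stronger inhibition and higher numbers for weaker inhibition. Compound 1 (`O=C(c1cc2cnc(Nc3ccc(N4CCNCC4)cn3)nc2n1C1CCCC1)N1CCCCC1`), with piperidin-1-yl on the carbonyl carbon, gives 39600 nM. Compound 2 (`COc1cccc(NC(=O)c2cc3cnc(Nc4ccc(N5CCNCC5)cn4)nc3n2C2CCCC2)c1`), with (3-methoxyphenyl)amino on that carbon, gives 2650 nM. Compound 3 (`O=C(Nc1ccccc1F)c1cc2cnc(Nc3ccc(N4CCNCC4)cn3)nc2n1C1CCCC1`), with (2-fluorophenyl)amino there, gives 3670 nM. Compound 3 therefore lies within the scatter of compound 2, and both sit well under compound 1.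

Compound 4 (`O=C(Nc1ccccc1C(F)(F)F)c1cc2cnc(Nc3ccc(N4CCNCC4)cn3)nc2n1C1CCCC1`) carries trifluoromethyl in place of fluoro on an aromatic carbon, ortho to a large group: trifluoromethyl in place of fluoro on an aromatic carbon. Among the compounds with values here, no measured step makes this exact exchange. The two large steps, a 15-fold lower number from compound 1 to compound 2 (1.17 log units; beyond the scatter) and an 11-fold lower number from compound 1 to compound 3 (1.03 log units; beyond the scatter), both replace piperidin-1-yl, a change that compound 4 does not make. The closest evidence is a 1.4-fold higher number from compound 2 to compound 3 (0.14 log units; within the scatter), which also exchanges one substituted phenyl for another on the amide-type nitrogen. On these data alone, on that single comparison, no step beyond the scatter is expected in this assay, though the direction remains open. The expected outcome is a 1.1-fold higher number from compound 3 to compound 4 (0.04 log units; within the scatter) as an estimate. For compound 4 the estimated value is 4000 nM, with an expected range from 1700 nM to 9500 nM.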

Compound 4, half-maximal inhibitory concentration: 3160 nM
Estimate against measurement, compound 4: 1.3-fold (0.10 log units) above; low and high end bracket the measured number.
By their numbers in this assay, from the lowest: compounds 2, 4 and 3 (each within the scatter of the next); then compound 1.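

In this assay, trifluoromethyl in place of fluoro on an aromatic carbon, ortho to a large group, gives a 1.2-fold lower number from compound 3 to compound 4 (0.06 log units; within the scatter), so a group of four heavy atoms and a single fluorine are not told apart at this place. Compound 4 also stays level with the 3-methoxyphenyl amide, with a 1.2-fold higher number from compound 2 to compound 4 (0.08 log units; within the scatter), while the replacement of piperidin-1-yl is again large, with a 13-fold lower number from compound 1 to compound 4 (1.10 log units; beyond the scatter), so all three arylamino compounds lie well under compound 1 and none of the compounds shown goes against this. No measurement bears on why these substituents leave the number unmoved.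

The compounds shown leave open whether an amine or a carboxylic acid at this place on the aromatic ring, groups unlike fluoro and trifluoromethyl in carrying hydrogen-bond donors, would move the number beyond the scatter. Also open, on these data alone, is whether benzylamino on the carbonyl carbon, with a carbon inserted before the ring, would stand with compound 2, compound 3 and compound 4 or with compound 1.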